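Working notes: cytotoxicity and a second chloro group

The compounds below may be only part of what the source reports. "The series", "measured", "known", "first", "only" and "open" are said of these compounds alone.

Compound 1 `O=C(CCSc1nnc(-c2ccncc2)s1)Nc1ccc(Cl)cc1Cl`: > 50000 nM
Compound 2 `CC(CSc1nnc(-c2ccncc2)s1)C(=O)Nc1ccc(Cl)cc1`: > 50000 nM

In an ADME assay on BHK-21 cells (Mesocricetus auratus) for cytotoxicity, with a stated time of 3 days (on this read-out lower numbers stand for higher toxicity in this test and higher numbers for lower toxicity in this test), compound 1 gives > 50000 nM, which is a limit of the assay and not a number. In this assay compound 2 gives > 50000 nM, also only a limit. Compound 2 therefore stands at the ceiling of the measured range, together with the other value, as described by the limit of > 50000 nM in this assay, at which 2 of the 2 values shown sit; no ordering between the two can be read from this.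

Compound 3 `CC(CSc1nnc(-c2ccncc2)s1)C(=O)Nc1ccc(Cl)cc1Cl` differs from compound 2 by chloro in place of hydrogen on an aromatic carbon. Among the compounds with values here, no measured step between compounds is available, so the expectation rests on the two limits alone. In this assay, within the data shown here, the step from compound 2 to compound 3 is expected to be none beyond the scatter, because both values so far sit at the limit (the limit of > 50000 nM in this assay, at which 2 of the 2 values shown sit); that is, a number no higher from compound 2 to compound 3 (the limit leaves the size open) is the estimated step. Compound 3 is estimated at 50000 nM, with a range from 20000 nM to 100000 nM, most likely reported again as a limit.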

Compound 3, half-maximal cytotoxic concentration: > 50000 nM
Compound 3: no number, only a limit (the forecaster's own chance of this, stated with the estimate: 75%); the middle value sits exactly at the limit.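

No step can be read from compound 2 to compound 3 or from compound 1 to compound 3 in this assay because all three compounds give only a limit of the assay: the limit of > 50000 nM in this assay, at which 3 of the 3 values shown sit.

The compounds shown leave open whether chloro or methyl in place of hydrogen changes the half-maximal cytotoxic concentration at all.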